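Halogen swap on the aromatic ring: outlook for compound 3

A few compounds are considered here, and "the series" means these few. Any claim that something is new, unique, unknown or untested is made for them only; others in the source may bear on it.

compound 1 `COc1ccc(OCC2=NCCO2)cc1` — 33.2%
compound 2 `Brc1ccc(OCC2=NCCO2)cc1` — 48.5%

In a functional assay on the whole organism for inhibition, with Rattus norvegicus as the target, read by paw edema, with a stated time of 30 min, at a dose of 40 mg/kg by the oral route (on this read-out higher numbers stand for a stronger effect at the one dose given and lower numbers for a weaker effect), compound 1 gives 33.2% and compound 2 gives 48.5%. Compound 2 stands highest of the two numbers; the nearest is compound 1, and the gap between them is beyond the scatter: a number 15.3 percentage points higher from compound 1 to compound 2 (beyond the scatter).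

Compound 3 `Fc1ccc(OCC2=NCCO2)cc1` is not yet measured. It differs from compound 2 by fluoro in place of bromo on an aromatic carbon. For the measured compounds named here, no measured step exchanges one halogen for another. Going by the values given here, the only step available, a number 15.3 percentage points higher from compound 1 to compound 2 (beyond the scatter), is modest and shows what bromo brings over methoxy, not what fluoro brings over bromo, so it bears on the present change only loosely. The expectation is therefore a modest fall from compound 2, possibly no larger than the scatter, and the estimated step is a number 10.5 percentage points lower from compound 2 to compound 3 (beyond the scatter). Compound 3 is estimated at 38%, with a range from 24% to 52%.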

Compound 3, a percentage reported as inhibition, in the whole organism at one dose (the size of the read-out at that dose, not a potency): 30.2%
Estimate against measurement, compound 3: 7.8 percentage points above, within the range that was stated.
By their numbers in this assay, from the lowest: compounds 3 and 1 (each within the scatter of the next); then compound 2.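

In this assay the halogens at this aromatic carbon are not interchangeable: fluoro in place of bromo gives a number 18.3 percentage points lower from compound 2 to compound 3 (beyond the scatter) and so does not keep the higher read-out of compound 2. Fluoro in place of methoxy gives a number 3 percentage points lower from compound 1 to compound 3 (within the scatter) and so separates neither group from the other, which leaves bromo as the only one of the three groups standing apart at the single dose, with its steps to both others beyond the scatter. No measurement on hand bears on why bromo differs from fluoro here.

Going by these compounds, what chloro or iodo would give at this carbon stays open, and with it whether the read-out follows any order among the halogens. Also open, on these data alone, is how an amine, a carboxylic acid or a longer alkoxy chain would fare at this place on the shared core.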